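The compounds below may be only part of what the source reports. "The series", "measured", "known", "first", "only" and "open" are said of these compounds alone.

Of the compounds shown here, three built on one shared core have been tested in a functional assay (trachea) with Cavia porcellus as the target; a higher number here means a weaker inhibitor, a lower number a stronger inhibitor. Compound 1 `CC(=O)Cn1nc(-c2cccnc2)c2ccccc2c1=O`, which carries an acetyl group on its side chain, gives 40700 nM. Compound 2 `O=c1c2ccccc2c(-c2cccnc2)nn1CCSc1ncccn1` gives 11000 nM. Compound 3 `O=C(O)Cn1nc(-c2cccnc2)c2ccccc2c1=O` gives > 100000 nM, which is a limit of the assay and not a number.

Compound 4 `O=C(O)CCCn1nc(-c2cccnc2)c2ccccc2c1=O` is the next to be examined, and it differs from compound 3 as follows: 2-carboxyethyl in place of carboxy on a saturated chain carbon bound to an aromatic nitrogen. In words, 2-carboxyethyl stands in place of carboxy on a saturated chain carbon bound to an aromatic nitrogen, so carboxymethyl becomes 3-carboxypropyl.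

For the measured compounds named here, no measured step lengthens this chain, so the evidence is indirect. Two steps introduce the carboxy-ending side chain, an at least 2.4-fold higher number from compound 1 to compound 3 (0.39 log units; beyond the scatter) and an at least 9.0-fold higher number from compound 2 to compound 3 (0.95 log units; beyond the scatter), and both go towards weaker inhibition. Compound 4 keeps that carboxy group, which argues against a large gain. Still, a 3.7-fold lower number from compound 1 to compound 2 (0.57 log units; beyond the scatter) shows that changing this side chain can shift the number modestly in the stronger direction.

A small shift towards a lower number in this assay is therefore expected, estimated as an at least 1.6-fold lower number from compound 3 to compound 4 (0.22 log units; that floor lies within the scatter). The expected value for compound 4 is 60000 nM, within an estimated range of 20000 nM to 150000 nM.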

Compound 4, half-maximal inhibitory concentration: > 100000 nM
Compound 4 gave a limit, no number; the forecaster's own chance of this, stated with the estimate: 50%; middle value at least 1.6-fold (0.22 log units) from the limit.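

Extending carboxymethyl to 3-carboxypropyl does not bring a carboxy-ending side chain into the readable range of this assay. The step from compound 3 to compound 4 cannot be read, since both compounds sit at the same limit of the assay, which is not a number: the limit of > 100000 nM in this assay, at which 2 of the 4 values shown sit. Even so, the longer acid stays well on the weak side of the two compounds with other side-chain ends, with an at least 9.0-fold higher number from compound 2 to compound 4 (0.95 log units; beyond the scatter) and an at least 2.4-fold higher number from compound 1 to compound 4 (0.39 log units; beyond the scatter), so among these four compounds weak inhibition goes with a carboxy end at both chain lengths, and neither carboxy compound goes against this.

On these data alone, how far compound 3 and compound 4 lie beyond the limit stays unknown, so a small effect of chain length could be hidden there. As far as these compounds go, it also remains open whether an amine or a primary amide at the end of the 3-carboxypropyl chain would give a readable value, and whether the sulfur or the pyrimidine ring of compound 2 accounts for its lower number.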